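Urea series: moving the chloro substituent on the N-aryl ring

The source may hold more compounds than are shown below. What is called first, only, known or untested is meant among the compounds shown, and "the series" means these compounds.

Three ureas on the shared core have been measured in an assay on CHO-K1 cells for antagonist activity at transient receptor potential cation channel subfamily V member 1 (Homo sapiens), read by FLIPR and calcium flux, with a stated time of 6 min; on this read-out higher numbers stand for weaker inhibition and lower numbers for stronger inhibition. Compound 1 `Cn1ncc2c(NC(=O)NCc3cc(C(C)(C)C)nn3-c3cccc(Cl)c3)cccc21` gives 0.4 nM, compound 2 `Cn1ncc2c(NC(=O)NCc3cc(C(F)(F)F)nn3-c3ccc(Cl)cc3)cccc21` gives 2.7 nM, and compound 3 `Cn1ncc2c(NC(=O)NCc3cc(C(C)(C)C)nn3-c3cccc(C(F)(F)F)c3)cccc21` gives 0.6 nM. Compound 3 holds the second highest of the three numbers in this assay; compound 1 lies within the scatter of it, whereas compound 2 is beyond the scatter from it. Within the data shown here, the one single-point step on record, a 1.5-fold higher number from compound 1 to compound 3 (0.18 log units; within the scatter), stays within the scatter.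

Compound 4 `Cn1ncc2c(NC(=O)NCc3cc(C(C)(C)C)nn3-c3ccc(Cl)cc3)cccc21` is the next step: 4-chlorophenyl in place of 3-(trifluoromethyl)phenyl on an aromatic nitrogen. Among the measured compounds shown here, no measured step bears directly on this change; compound 2 also carries 4-chlorophenyl but differs from compound 4 elsewhere, so its value only sets a loose reference. A modest rise in the number is expected, with the step from compound 3 to compound 4 estimated at a 2.5-fold higher number from compound 3 to compound 4 (0.40 log units; beyond the scatter). Compound 4 is therefore estimated at 1.5 nM in this assay, with a range from 0.4 nM to 6 nM.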

Compound 4, inhibition constant: 9.5 nM
Estimate against measurement, compound 4: 6.3-fold (0.80 log units) below; measured number above the stated range.
By their numbers in this assay, from the lowest: compounds 1 and 3 (each within the scatter of the next); then compound 2; then compound 4.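

On the aromatic nitrogen, the position of the substituent carries the change: 4-chlorophenyl in place of 3-chlorophenyl gives a 24-fold higher number from compound 1 to compound 4 (1.38 log units; beyond the scatter), and 4-chlorophenyl in place of 3-(trifluoromethyl)phenyl gives a 16-fold higher number from compound 3 to compound 4 (1.20 log units; beyond the scatter), although those two groups had stayed within the scatter of each other. With 4-chlorophenyl held, tert-butyl in place of trifluoromethyl gives a 3.5-fold higher number from compound 2 to compound 4 (0.55 log units; beyond the scatter). No evidence on hand accounts for these steps.

Open: how 3-chlorophenyl behaves with trifluoromethyl in place of tert-butyl, and whether an amine or carboxylic acid on the phenyl ring keeps the number low.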